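The compounds below may be only part of what the source reports. "The series", "measured", "known", "first", "only" and "open" are said of these compounds alone.

Within the data shown here, in a functional assay on DU-145 cells (Homo sapiens) for inhibition, read by trypan blue exclusion, with a stated time of 72 h (a higher number here means a weaker inhibitor, a lower number a stronger inhibitor), three compounds have numbers so far. Compound 1 `O=c1c(S(=O)(=O)c2ccc(F)cc2F)cc2cnc(Nc3ccc4[nH]ccc4c3)nc2n1C1CCCC1` gives 5000 nM, the highest of the three. Compound 2 `Cc1cc2cc(Nc3ncc4cc(S(=O)(=O)c5ccc(F)cc5F)c(=O)n(C)c4n3)ccc2[nH]1` gives 750 nM, and compound 3 `Cn1c(=O)c(S(=O)(=O)c2ccc(F)cc2)cc2cnc(Nc3cccc4[nH]ccc34)nc21` gives 750 nM. Each of these two sits below compound 1 by a gap beyond the usual scatter of repeated measurements.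

Compound 4 `O=c1c(S(=O)(=O)c2ccc(F)cc2F)cc2cnc(Nc3ccc4[nH]ccc4c3)nc2n1C1CC1` has not yet been measured. It keeps the core of compound 1 and changes a single group: cyclopropyl in place of cyclopentyl on an aromatic nitrogen. Among the measured compounds shown here, no two measured compounds differ in only one place, so the data hold no direct test of this swap. The only hint is indirect. Compound 2 at 750 nM and compound 3 at 750 nM carry a methyl on that same nitrogen, a smaller group than cyclopentyl, but both also differ from compound 1 elsewhere.

On that cautious basis, a modest move toward a lower number is expected, one that may only just clear the scatter. The expected change is a 2.5-fold lower number from compound 1 to compound 4 (0.40 log units; beyond the scatter). For compound 4 the estimated value is 2000 nM, with an expected range from 600 nM to 6000 nM.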

Compound 4, half-maximal inhibitory concentration: 500 nM
Compound 4: middle estimate off by 4.0-fold (0.60 log units), on the high side; measured number below the stated range.
By their numbers in this assay, from the lowest: compounds 4, 2 and 3 (each within the scatter of the next); then compound 1.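

In this assay, the step from cyclopentyl to cyclopropyl on the aromatic nitrogen gives a 10-fold lower number from compound 1 to compound 4 (1.00 log units; beyond the scatter), with the rest of the molecule unchanged. Among these compounds, this is the first direct reading of this position, and it shows that the group on this nitrogen can by itself move the number by well beyond the scatter. Nothing available explains how this swap produces the shift, so the result stands as an observation without a cause.

From the compounds shown here alone, a single pair gives two points rather than a trend, so it remains open whether the number depends on ring size, on the particular cyclopropyl ring, or on something else about these two groups. Also open, going by these compounds, is how an open chain such as isopropyl, or a chain ending in an amine or a carboxylic acid, would behave on this nitrogen, and whether the effect of cyclopropyl would carry over to a compound with a different group on the sulfonyl or a different group on the shared core.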